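The compounds below may be only part of what the source reports. "The series", "measured", "known", "first", "only" and "open" are said of these compounds alone.

In an ADME assay on Vero cells (Chlorocebus sabaeus) for cytotoxicity, read by neutral red uptake (a lower number here means that less compound is tolerated, a higher number that more compound is tolerated), compound 1 (`CC1(C)CC(=O)C(=C/C=C/c2ccccc2)C(=O)C1`) gives > 18.7 uM as a limit, not a number. Compound 2 (`CC1(C)CC(=O)C(=CC=C(c2ccccc2)c2ccccc2)C(=O)C1`) gives > 14.4 uM as a limit too. For the measured compounds named here, no two measured compounds differ in one place, so the series offers no measured step to go by. Compound 3 (`CC1(C)CC(=O)C(=C/C=C/c2ccc(F)cc2)C(=O)C1`), still unmeasured, differs from compound 1 by fluoro in place of hydrogen on an aromatic carbon with fluoro in place of hydrogen on an aromatic carbon. The expected at least 1.0-fold lower number from compound 1 to compound 3 (0.01 log units; that floor lies within the scatter) stays within the scatter, in neither direction. For compound 3 the estimate is 18 uM with an expected range of 8 uM to 40 uM and a limit, rather than a number, is the likely report.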

Compound 3, half-maximal toxic concentration: > 17.5 uM
Compound 3: a limit, no number; the forecaster's own chance of this, stated with the estimate: 75%; the middle value lies beyond the limit too.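

In this assay, compound 1 and compound 3 both stand as limits, not numbers, and the step between them cannot be read. The compounds shown leave open whether fluoro in place of hydrogen on an aromatic carbon changes the concentration tolerated at all.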